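Ethyl in Place of Nitrophenyl on the Ring Nitrogen

The source may hold more compounds than are shown below. What is called first, only, known or untested is meant among the compounds shown, and "the series" means these compounds.

Compound 1, `COc1ccc(Cc2nn(-c3ccccc3)c(=O)c3ccccc23)cc1OC`, in a functional assay on aorta with Alpha-1D adrenergic receptor (Rattus norvegicus) as the target (on this read-out lower numbers stand for an effect already at smaller amounts and higher numbers for an effect only at larger amounts of compound), gives > 100000 nM; this is a limit of the assay, not a number.
Compound 2, `CCCCn1nc(Cc2ccc(OC)c(OC)c2)c2ccccc2c1=O`, in this assay gives 5400 nM.
Compound 3, `COc1ccc(Cc2nn(-c3ccc([N+](=O)[O-])cc3)c(=O)c3ccccc23)cc1OC`, in this assay gives > 100000 nM; this too is a limit, not a number.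

Compound 3 therefore stands only at a limit, and it shares that position with one other compound: the limit of > 100000 nM in this assay, at which 2 of the 3 values shown sit. Compound 4, `CCn1nc(Cc2ccc(OC)c(OC)c2)c2ccccc2c1=O`, has not yet been measured. The change is ethyl in place of 4-nitrophenyl on an aromatic nitrogen. Among the compounds with values here, two measured steps bear on it. Replacing a plain phenyl on that nitrogen with butyl gave an at least 18-fold lower number from compound 1 to compound 2 (1.26 log units; beyond the scatter), and going the other way from butyl to 4-nitrophenyl gave an at least 18-fold higher number from compound 2 to compound 3 (1.26 log units; beyond the scatter). Both say that an alkyl chain on this nitrogen is far better tolerated than an aryl ring. For compound 4 the step to a shorter chain is expected to be large and downward, an at least 8.3-fold lower number from compound 3 to compound 4 (0.92 log units; beyond the scatter), though whether ethyl matches butyl is not known. Compound 4 is estimated at 12000 nM, within 3000 nM to 50000 nM.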

Compound 4, half-maximal effective concentration: 5300 nM
Compound 4: middle estimate off by 2.3-fold (0.35 log units), on the high side; measured number inside the range.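

Ethyl in place of butyl on the aromatic nitrogen gives a 1.0-fold lower number from compound 2 to compound 4 (0.01 log units; within the scatter) in this assay, so the butyl chain is not a special case and the two chain lengths cannot be told apart on this read-out. Ethyl also gives an at least 18-fold lower number from compound 3 to compound 4 (1.27 log units; beyond the scatter) and an at least 18-fold lower number from compound 1 to compound 4 (1.27 log units; beyond the scatter), so a second alkyl chain now stands clear of both the plain phenyl and the 4-nitrophenyl ring. How far these two steps truly reach stays unknown, because both aryl compounds stand at a limit of the assay, not at a number: the limit of > 100000 nM in this assay, at which 2 of the 4 values shown sit.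

Going by these compounds, it remains open whether a methyl group or a longer chain such as octyl would fit the same picture. The compounds shown also do not tell whether a benzyl group, or a chain ending in an amine, would read like the alkyl chains or like the aryl rings.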